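This account rests on a few compounds, and the source may have more. Where it says the series, first, only, none or still open, it means among the compounds named here.

Of the compounds shown here, three have been measured in a functional assay on NCI-H460 cells (Homo sapiens) for inhibition, read by MTT assay, with a stated time of 72 h; on this read-out higher numbers stand for weaker inhibition and lower numbers for stronger inhibition. Compound 1 `COc1cc2c(Oc3ccc(NC(=O)c4nn(-c5ccccc5C)c(=O)cc4C)cc3F)ccnc2cc1OCCCN1CCCCC1` gives 3220 nM. Compound 2 `COc1cc2c(Oc3ccc(NC(=O)c4nn(-c5ccccc5C(F)(F)F)c(=O)cc4C)cc3F)ccnc2cc1OCCCN1CCCCC1` gives 210 nM, and compound 3 `COc1cc2c(Oc3ccc(NC(=O)c4nn(-c5ccccc5OC(F)(F)F)c(=O)cc4C)cc3F)ccnc2cc1OCCCN1CCCC1` gives 210 nM. Compound 3 thus stands level with compound 2 at the digits shown, and these two together give the lowest numbers of the three; the only measured single change is a 15-fold lower number from compound 1 to compound 2 (1.19 log units; beyond the scatter), where the difference is a trifluoromethyl in place of a methyl on an aromatic carbon.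

Compound 4 `COc1cc2c(Oc3ccc(NC(=O)c4nn(-c5ccccc5OC(F)(F)F)c(=O)cc4C)cc3F)ccnc2cc1OCCCN1CCCCC1` differs from compound 3 in one place: piperidin-1-yl in place of pyrrolidin-1-yl on a saturated chain carbon, three bonds along the chain from an oxygen on an aromatic ring. Among the measured compounds shown here, no measured step touches this part of the molecule, so nothing among the three measured compounds speaks for or against a change here; compound 2 also carries the piperidin-1-yl group, but it differs from compound 3 in a second place as well, so its value cannot be read as a step. Without a bearing step, the expectation is a step of no change at the digits printed from compound 3 to compound 4 (within the scatter), that is, none beyond the scatter. Compound 4 is therefore estimated at 210 nM, with a range from 90 nM to 500 nM.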

Compound 4, half-maximal inhibitory concentration: 230 nM
Estimate against measurement, compound 4: 1.1-fold (0.04 log units) below; low and high end bracket the measured number.
By their numbers in this assay, from the lowest: compounds 2, 3 and 4 (each within the scatter of the next); then compound 1.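

In this assay the step of a 1.1-fold higher number from compound 3 to compound 4 (0.04 log units; within the scatter) shows that, with trifluoromethoxy on the aromatic ring, the 3-(pyrrolidin-1-yl)propyl and 3-(piperidin-1-yl)propyl chains cannot be told apart. With piperidin-1-yl held constant, the aromatic group can now be compared as well: trifluoromethoxy in place of trifluoromethyl gives a 1.1-fold higher number from compound 2 to compound 4 (0.04 log units; within the scatter) and trifluoromethoxy in place of methyl gives a 14-fold lower number from compound 1 to compound 4 (1.15 log units; beyond the scatter), so among these three groups only methyl stands apart. No data at hand explain these results.

Going by these compounds, whether the same holds for other amines on the chain, such as morpholine or dimethylamine, or for a shorter or longer chain, remains open. Also open, on these data alone, is whether the two rings would still match with methyl or trifluoromethyl on the aromatic ring in place of trifluoromethoxy.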